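Working notes: aryl amide change from compound 1 to compound 4

This account rests on a few compounds, and the source may have more. Where it says the series, first, only, none or still open, it means among the compounds named here.

Measured so far in a functional assay on PC-3 cells (Homo sapiens) for cytotoxicity; on this read-out lower numbers stand for stronger inhibition of growth and higher numbers for weaker inhibition of growth:
- compound 1 `Cc1ccc(S(=O)(=O)N2c3ccccc3CC2C(=O)Nc2cc(Cl)cc(Cl)c2)cc1`: > 10000 nM (a limit of the assay, not a number)
- compound 2 `O=C(Nc1cc(C(F)(F)F)ccc1C(F)(F)F)C1Cc2ccccc2N1`: 794 nM
- compound 3 `CC(NC(=O)OC(C)(C)C)C(=O)N1c2ccccc2CC1C(=O)Nc1ccc(C(C)(F)F)cc1`: 6260 nM

Compound 1 sits at the limit of this assay, as the limit of > 10000 nM in this assay, at which 1 of the 3 values shown sits, shows, so no number is known for it. Compound 2, which carries no group on the ring nitrogen of the shared core, gives 794 nM in this assay. For the measured compounds named here, compound 3, with a different group on that nitrogen and a different aryl amide, gives 6260 nM in this assay; these two values differ from each other beyond the scatter, but neither compound shares one change with compound 1, so no step is computed.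

Compound 4 `Cc1ccc(S(=O)(=O)N2c3ccccc3CC2C(=O)Nc2ccc(C(F)(F)F)cc2)cc1` keeps the core of compound 1 and changes the aryl amide: 4-(trifluoromethyl)phenyl in place of 3,5-dichlorophenyl on an amide-type nitrogen. Because compound 1 sits at the limit of > 10000 nM in this assay, at which 1 of the 3 values shown sits, the step of an at least 1.2-fold lower number from compound 1 to compound 4 (0.09 log units; that floor lies within the scatter) that the estimate means cannot be sized against a measured number; a gain is expected, but a modest one. Compound 4 is expected to give 8000 nM in this assay, within 2000 nM to 30000 nM.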

Compound 4, concentration for 50% growth inhibition: 6680 nM
For compound 4 the middle estimate is 1.2-fold (0.08 log units) above the measured one; the measured number falls inside the stated range.
By their numbers in this assay, from the lowest: compound 2; then compounds 3 and 4 (each within the scatter of the next). At a limit, above all of these: compound 1.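

For the compounds shown here, compound 4 gives the first pair with a single change, at the amide-type nitrogen, while the core of compound 1 and the group on its ring nitrogen stay fixed; in this assay compound 4 gives 6680 nM, so this change alone yields a number on the scale. Compound 1 gives > 10000 nM, which is a limit of the assay and not a number. Replacing 3,5-dichlorophenyl with 4-(trifluoromethyl)phenyl gives an at least 1.4-fold lower number from compound 1 to compound 4 (0.17 log units; that floor lies within the scatter), and that floor is all that can be read, because one end of the step is not a number: the limit of > 10000 nM in this assay, at which 1 of the 4 values shown sits.

The compounds shown leave open whether losing the two chlorines or gaining the trifluoromethyl carries the step. Going by these compounds, how this position responds to an aryl amide bearing a carboxylic acid or an amine in place of trifluoromethyl also stays open.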